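The source may hold more compounds than are shown below. What is called first, only, known or untested is meant among the compounds shown, and "the series" means these compounds.

Measured so far:
compound 1, `Nc1nc(O)c2c(n1)n(C1OC(CO)[C@@H](O)[C@H]1O)c(=O)n2Cc1ccc(Cl)c(Cl)c1`: 0%
compound 2, `Cn1c(=O)n([C@@H]2O[C@H](CO)[C@H]3OC(C)(C)O[C@H]32)c2nc(N)nc(O)c21`: 17%
compound 3, `C=CCn1c(=O)n([C@@H](CO)OC(CO)CO)c2nc(N)nc(O)c21`: 6%

These three values come from a functional assay on the whole organism with Mus musculus as the target; a lower number here means a smaller maximal response, a higher number a larger maximal response. Compound 1 stands lowest of the three measured numbers; its gap to compound 3 lies within the usual scatter of this kind of measurement, while compound 2 sits beyond that scatter from it. Compound 4, `NC(=O)Cn1c(=O)n(C2OC(CO)[C@@H](O)[C@H]2O)c2nc(N)nc(O)c21`, has not been measured yet. It differs from compound 1 in one place: carbamoyl in place of 3,4-dichlorophenyl on a saturated chain carbon bound to an aromatic nitrogen. Going by the values given here, no two measured compounds differ in just one place, so no measured step guides this change. All three measured values are low, so compound 4 is expected to stay low as well, with the expected step of a number 5 percentage points higher from compound 1 to compound 4 (within the scatter) small and not beyond the scatter. The estimate for compound 4 is 5%, in a range from 0% to 18%.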

Compound 4, largest response reached (reported as maximal response), in percent of the reference or control that the assay uses: 72%
Beside the measured number, compound 4's estimate is 67 percentage points below it, outside the stated range (above it).
By their numbers in this assay, from the lowest: compounds 1 and 3 (each within the scatter of the next); then compound 2; then compound 4.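

In this assay, replacing 3,4-dichlorobenzyl with carbamoylmethyl gives a number 72 percentage points higher from compound 1 to compound 4 (beyond the scatter) on the shared core. Going by these compounds alone, this is the first single change that can be read here, and it shows that the group on this saturated chain carbon bound to an aromatic nitrogen can decide between almost no response and a strong one. One pair cannot separate the gain from the carbamoyl from the loss of the 3,4-dichlorophenyl, and a carboxylic acid, an amine or a longer chain at this place would test that. Nothing at hand gives a reason for the rise.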